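The source may report more compounds than this note shows. Statements on the series, on what has been measured and on what is new or still open speak of the compounds shown alone.

Compound 1 `CCCCc1ccc(CNC(=O)OC(C)(C)C)c(=O)n1Cc1ccc(-c2ccccc2-c2nn[nH]n2)cc1` carries a (tert-butoxycarbonyl)amino group on a saturated chain carbon bound to an aromatic carbon. In a functional assay (aorta) for antagonist activity, with Oryctolagus cuniculus as the target (on this read-out lower numbers stand for stronger inhibition and higher numbers for weaker inhibition), compound 1 gives 10 nM, level with compound 2 `CCCCNC(=O)NCc1ccc(CCCC)n(Cc2ccc(-c3ccccc3-c3nn[nH]n3)cc2)c1=O`, which gives 10 nM, while compound 3 `CCCCc1ccc(CN(C(C)C)S(C)(=O)=O)c(=O)n1Cc1ccc(-c2ccccc2-c2nn[nH]n2)cc1` gives 0.9 nM, the lowest of the three. The step of no change at the digits printed from compound 1 to compound 2 (within the scatter) leaves the number untouched, whereas an 11-fold lower number from compound 1 to compound 3 (1.05 log units; beyond the scatter) and an 11-fold lower number from compound 2 to compound 3 (1.05 log units; beyond the scatter) show that what sits on that chain carbon can shift it far. Compound 4 `CCCCc1ccc(C)c(=O)n1Cc1ccc(-c2ccccc2-c2nn[nH]n2)cc1` differs from compound 1 by hydrogen in place of (tert-butoxycarbonyl)amino on a saturated chain carbon bound to an aromatic carbon. Among the compounds with values here, no measured step removes the group outright, so its direction is uncertain. Compound 4 is therefore expected to give 30 nM (range 8 nM to 120 nM), the expected step of a 3.0-fold higher number from compound 1 to compound 4 (0.48 log units; beyond the scatter) leaning toward a higher number.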

Compound 4, half-maximal inhibitory concentration: 7 nM
Compound 4: middle estimate off by 4.3-fold (0.63 log units), on the high side; the measured number lies below the stated range.
By their numbers in this assay, from the lowest: compound 3; then compounds 4, 1 and 2 (each within the scatter of the next).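

Removing the (tert-butoxycarbonyl)amino group or the (butylcarbamoyl)amino group outright, leaving a plain methyl, moves nothing beyond the scatter (a 1.4-fold lower number from compound 1 to compound 4 (0.15 log units; within the scatter)) and (a 1.4-fold lower number from compound 2 to compound 4 (0.15 log units; within the scatter)), so neither group contributes measurably on this saturated chain carbon. Within the data shown here, only isopropyl(methylsulfonyl)amino stands apart from hydrogen (a 7.8-fold higher number from compound 3 to compound 4 (0.89 log units; beyond the scatter)), which makes it the one group here that lowers the number from the level of the bare methyl. The compounds leave open whether the isopropyl or the methylsulfonyl part carries that gain, and how a free amine or a carboxylic acid would read on this carbon. Nothing measured here gives a cause for these steps.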